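The source may hold more compounds than are shown below. What is called first, only, known or untested is meant among the compounds shown, and "the series" means these compounds.

Measured in an ADME assay on BaF3 cells (Mus musculus) for antiproliferative activity, read by CCK-8 assay, with a stated time of 72 h; a higher number here means a weaker inhibitor of growth, a lower number a stronger inhibitor of growth:
- compound 1 `CNC(=O)CCSc1ccc2c(/C=C/c3ccccn3)n[nH]c2c1`: > 10000 nM
- compound 2 `O=C(CCSc1ccc2c(/C=C/c3ccccn3)n[nH]c2c1)Nc1ccccc1`: 690 nM
- compound 3 `O=C(CCSc1ccc2c(/C=C/c3ccccn3)n[nH]c2c1)Nc1cccc(Cl)c1`: 9350 nM

Compound 1 has no number in this assay: its > 10000 nM is a limit of the assay and not a measured value.

The next change leads to compound 4 `Cc1ccc(NC(=O)CCSc2ccc3c(/C=C/c4ccccn4)n[nH]c3c2)cc1`, which carries 4-methylphenyl in place of methyl on an amide-type nitrogen.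

Two measured steps make the same kind of exchange at this nitrogen, and they disagree. With phenyl the step is large: an at least 14-fold lower number from compound 1 to compound 2 (1.16 log units; beyond the scatter). With 3-chlorophenyl, the step shows no change beyond the scatter: an at least 1.0-fold lower number from compound 1 to compound 3 (0.02 log units; that floor lies within the scatter). The third step shows how much one ring substituent can matter, and it too is large: a 14-fold higher number from compound 2 to compound 3 (1.13 log units; beyond the scatter).

Compound 4 also has one substituent on the phenyl ring, though a methyl rather than a chloro and at a different place. A lower number than that of compound 1 is therefore expected, but probably less of a gain than compound 2 shows with 690 nM. The expected step is an at least 5.0-fold lower number from compound 1 to compound 4 (0.69 log units; beyond the scatter). For compound 4 the estimate is 2000 nM, with an expected range from 450 nM to 9000 nM.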

Compound 4, concentration for 50% growth inhibition: > 10000 nM
Compound 4 ended at the assay's limit (the forecaster's own chance of this, stated with the estimate: 15%); middle value at least 5.0-fold (0.69 log units) from the limit.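

A single methyl in place of hydrogen on the aromatic carbon of the phenyl ring is enough to produce a large step: an at least 14-fold higher number from compound 2 to compound 4 (1.16 log units; beyond the scatter). With this result, the unsubstituted phenyl of compound 2 is the only group on the amide-type nitrogen among those shown that gives a measured number well clear of the limit, and the gain it brings does not survive either ring substituent shown. No difference can be claimed between 3-chlorophenyl and 4-methylphenyl, since the floor of this step lies within the scatter: an at least 1.0-fold higher number from compound 3 to compound 4 (0.02 log units; that floor lies within the scatter).

The step from compound 1 to compound 4 cannot be read, as both ends are limits: the limit of > 10000 nM in this assay, at which 2 of the 4 values shown sit.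

Compound 3 and compound 4 differ both in the substituent and in its place on the ring, which leaves open whether the kind of group or its place matters more. Going by these compounds, how a fluoro on the phenyl ring, or a benzyl in place of the phenyl on the amide-type nitrogen, would read in this assay also stays open.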